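The compounds below may be only part of what the source reports. "The series", "measured", "known", "first", "only" and "open" are said of these compounds alone.

Compound 1 `O=C(O)c1cccc(C2CC2c2ccc(OCc3c(-c4c(Cl)cccc4Cl)noc3C3CC3)cc2Cl)c1`: 102%
Compound 2 `O=C(O)c1cncc(C2CC2c2ccc(OCc3c(-c4c(Cl)cccc4Cl)noc3C3CC3)cc2Cl)c1`: 103%

Both compounds were measured in an assay on isolated protein for agonist activity at Bile acid receptor (Homo sapiens), read by FRET; on this read-out higher numbers stand for larger maximal responses and lower numbers for smaller maximal responses. Within the data shown here, compound 2 has the numerically higher of the two values, but its only neighbour is compound 1, and the step of a number 1 percentage points higher from compound 1 to compound 2 (within the scatter) lies within the scatter, so the two cannot be told apart on this read-out. Compound 3 `Clc1cc(OCc2c(-c3c(Cl)cccc3Cl)noc2C2CC2)ccc1C1CC1c1ccc(-c2nnn[nH]2)nc1` has not yet been measured. It differs from compound 2 in one place: 6-(1H-tetrazol-5-yl)pyridin-3-yl in place of 5-carboxypyridin-3-yl on a saturated ring carbon. Among the measured compounds shown here, only one measured step bears on this change, a number 1 percentage points higher from compound 1 to compound 2 (within the scatter), which exchanged one acid-bearing aromatic ring for another and left the maximal response unchanged within the scatter. That step does not test the exchange of the carboxylic acid for a tetrazole, so the guide is incomplete; still, the response of compound 2, 103%, is expected to be largely retained. The step of a number 8 percentage points lower from compound 2 to compound 3 (within the scatter) is therefore expected to be small, not clearly beyond the scatter. Compound 3 is estimated at 95%, with a range from 75% to 112%.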

Compound 3, largest response reached (reported as efficacy), in percent of the reference or control that the assay uses: 101%
Compound 3: the middle estimate sits 6 percentage points below what was measured, within the range that was stated.
By their numbers in this assay, from the lowest: compounds 3, 1 and 2 (each within the scatter of the next).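

In this assay, placing 6-(1H-tetrazol-5-yl)pyridin-3-yl in the position held by 5-carboxypyridin-3-yl gave a number 2 percentage points lower from compound 2 to compound 3 (within the scatter), so on this saturated ring carbon the maximal response does not depend on a carboxylic acid, which both earlier compounds carried. Measured against the 3-carboxyphenyl group, the same exchange gave a number 1 percentage points lower from compound 1 to compound 3 (within the scatter), so all three groups remain indistinguishable on this read-out. Nothing available explains this tolerance of the tetrazole.

The compounds shown leave open whether the response would hold with a group carrying neither a carboxylic acid nor a tetrazole, such as a primary amide or a methyl ester. They also leave open whether these groups differ in potency, since this read-out reports only the largest response reached.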